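The source may hold more compounds than are shown below. What is called first, only, known or untested is meant among the compounds shown, and "the series" means these compounds.

Three compounds share a core built on a carbon with a double bond to nitrogen, whose other neighbours are two amide-type nitrogens, each carrying an aromatic carbonyl group. Compound 1 `C[Se]/C(=N\C(=O)c1cc2ccccc2s1)NC(=O)c1cc2ccccc2s1` and compound 2 `CS/C(=N\C(=O)c1sccc1Cl)NC(=O)c1sccc1Cl` both gave numbers in a functional assay on MCF7 cells (Homo sapiens) for cytotoxicity, read by MTT assay, with a stated time of 72 h; a lower number here means a stronger inhibitor of growth, a higher number a weaker inhibitor of growth. In this assay compound 1 gives 32700 nM, while compound 2 gives 57100 nM. Compound 3 `CS/C(=N\C(=O)c1ccno1)NC(=O)c1ccno1` is different in kind: in this assay compound 3 returns > 100000 nM, which is a limit of the assay rather than a measured number. Compound 3 therefore sits at the limit of > 100000 nM in this assay, at which 1 of the 3 values shown sits, and its true position cannot be read more closely than that.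

Compound 4 `O=C(/N=C(/NC(=O)c1ccno1)[Se]Cc1ccccc1)c1ccno1` has not yet been tested. It differs from compound 3 in a single place: a group of 8 heavy atoms (7 carbon, 1 selenium; one six-membered aromatic ring of carbon only) in place of a group of 2 heavy atoms (1 carbon, 1 sulfur; no ring), on a carbon with a double bond to nitrogen. Among the measured compounds shown here, no pair of measured compounds shows this change, so there is no measured step to lean on, and compound 3 itself offers only a limit as a starting point. The step in this assay is expected to be an at least 1.4-fold lower number from compound 3 to compound 4 (0.15 log units; that floor lies within the scatter), a move toward somewhat stronger growth inhibition that may not clear the usual scatter. Compound 4 is accordingly estimated at 70000 nM in this assay, within a range from 25000 nM to 200000 nM, and a further limit rather than a number remains quite possible.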

Compound 4, concentration for total growth inhibition: > 100000 nM
Compound 4: no number, only a limit; the forecaster's own chance of this, stated with the estimate: 45%; at least 1.4-fold (0.15 log units) between middle value and limit.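

Compound 3 and compound 4 both stand at a limit of this assay rather than at a number, so no step from compound 3 to compound 4 can be read: the limit of > 100000 nM in this assay, at which 2 of the 4 values shown sit.

The compounds shown leave open whether the group of 8 heavy atoms in place of methylsulfanyl changes growth inhibition at all, and where the true values of compound 3 and compound 4 lie.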